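Halogenated naphthyl ethers and cytotoxicity in C8166 cells

A few compounds are considered here, and "the series" means these few. Any claim that something is new, unique, unknown or untested is made for them only; others in the source may bear on it.

Of the compounds shown here, three have been tested in an ADME assay on C8166 cells (Homo sapiens) for cytotoxicity, read by MTT assay; a lower number here means that less compound is tolerated, a higher number that more compound is tolerated. Compound 1 `Cc1cc(S(N)(=O)=O)ccc1NC(=O)COc1ccc(F)cc1Oc1cccc2ccccc12` carries a naphthalen-1-yl group on the ether oxygen; in this assay compound 1 gives 33100 nM. Compound 2 `Cc1cc(S(N)(=O)=O)ccc1NC(=O)COc1ccc(F)cc1Oc1ccc2cc(Br)ccc2c1` bears 6-bromonaphthalen-2-yl instead, and in this assay compound 2 reaches only the limit > 357000 nM. Compound 3 `Cc1cc(S(N)(=O)=O)ccc1NC(=O)COc1ccc(F)cc1Oc1ccc2cc(C#N)ccc2c1`, with 6-cyanonaphthalen-2-yl, likewise reaches only the limit > 395000 nM in this assay. Compound 3 therefore stands at a limit rather than at a number, and of the other two values shown, one is also a limit (the limit of > 357000 nM in this assay, at which 1 of the 3 values shown sits). The steps of an at least 10-fold higher number from compound 1 to compound 2 (1.03 log units; beyond the scatter) and an at least 11-fold higher number from compound 1 to compound 3 (1.07 log units; beyond the scatter) are both large, while the step that the two limits leave unreadable from compound 2 to compound 3 cannot be read from the two limits.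

Compound 4 `Cc1cc(S(N)(=O)=O)ccc1NC(=O)COc1ccc(F)cc1Oc1ccc2ccccc2c1Cl` has not yet been measured in this assay. It differs from compound 3 in that (1-chloronaphthalen-2-yl in place of 6-cyanonaphthalen-2-yl on an oxygen on an aromatic ring). The substitution of one halogen-bearing naphthyl group for the cyano-bearing one resembles the comparison of compound 2 with compound 3, whose step is unreadable, so no direction is firmly set; the 2-naphthyl ethers both lie at limits, whereas compound 1 sits well lower. Compound 4 is expected at 150000 nM, in a range from 30000 nM to 400000 nM, which would mean an estimated step of an at least 2.6-fold lower number from compound 3 to compound 4 (0.42 log units; beyond the scatter), with a fair chance that only a limit is reported.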

Compound 4, half-maximal cytotoxic concentration: 47100 nM
Compound 4: middle estimate off by 3.2-fold (0.50 log units), on the high side, within the range that was stated.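

Compound 4 shows that a naphthalen-2-yl group on the oxygen does not by itself bring a compound to a limit in this assay: with 1-chloronaphthalen-2-yl in that place the series gives a measured number, with an at least 8.3-fold lower number from compound 3 to compound 4 (0.92 log units; beyond the scatter) and an at least 7.5-fold lower number from compound 2 to compound 4 (0.87 log units; beyond the scatter). The same group brings the reading back to the level of the naphthalen-1-yl ether, with a 1.4-fold higher number from compound 1 to compound 4 (0.15 log units; within the scatter), so these two compounds cannot be told apart in this assay although their naphthalene groups are joined differently and only one carries chloro. The value of compound 3 is a limit, so the step to compound 4 gives only a minimum size: the limit of > 395000 nM in this assay, at which 1 of the 4 values shown sits.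

On these data alone, the value of compound 2 is also a limit, so the steps that rest on it give only a minimum size and the step between the two limits cannot be read: the limit of > 357000 nM in this assay, at which 1 of the 4 values shown sits. Compound 4 differs from compound 2 in both the halogen and its place on the naphthalene, so it remains open whether 6-chloronaphthalen-2-yl or 1-aminonaphthalen-2-yl would read like compound 4 or reach a limit.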